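This account rests on a few compounds, and the source may have more. Where it says the series, first, only, none or still open, it means among the compounds named here.

The series centres on a diyne carrying a terminal hydroxy group, and the read-out throughout is a functional assay on L1210 cells (Mus musculus) for cytotoxicity, read by WST assay, with a stated time of 48 h; a lower number here means that less compound is needed, a higher number that more compound is needed for the effect. Compound 1 `C/C=C/C#CC#C[C@H](O)CCO` is the shortest member. In this assay compound 1 gives only a limit, > 10 ug/mL, and no number. Compound 3 `C=CCCCCC/C=C\C(O)C#CC#CC(O)C=C` carries a free hydroxy group at each end of the diyne; in this assay compound 3 gives 0.12 ug/mL. Compound 2 `C=CCCCCC/C=C\[C@H](O)C#CC#C[C@H](C=C)OC(C)=O` bears an acetate on one carbinol carbon and a defined stereocentre at both ends. In this assay compound 2 gives 2.1 ug/mL, which is the highest of the two numbers on record; its nearest neighbour is compound 3, which sits lower by a gap that lies beyond the scatter of the measurement.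

Compound 4 `C=CCCCCC/C=C\[C@H](O)C#CC#C/C=C/COC(C)=O` has the same atoms as compound 2, joined differently. The change is a group of 7 heavy atoms (5 carbon, 2 oxygen; no ring) in place of a group of 7 heavy atoms (5 carbon, 2 oxygen; no ring), on a triple-bonded carbon. Within the data shown here, no measured pair in the set isolates this rearrangement, so the step it brings can only be expected, not read off. He expects compound 4 to stay close to compound 2, with an estimate of 3 ug/mL, ranging from 0.7 ug/mL to 10 ug/mL, so that the expected step of a 1.4-fold higher number from compound 2 to compound 4 (0.15 log units; within the scatter) would remain within the scatter.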

Compound 4, concentration for half-maximal effect: 7.7 ug/mL
Compound 4: the middle estimate sits 2.6-fold (0.41 log units) below what was measured; the measured number falls inside the stated range.
By their numbers in this assay, from the lowest: compound 3; then compound 2; then compound 4. At a limit, above all of these: compound 1.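

Among these compounds, this is the first step that can be read between two compounds differing in one place: on a triple-bonded carbon, a 3-acetoxyprop-1-en-1-yl group replaces the group that holds the acetate on a defined stereocentre, and in this assay this gives a 3.7-fold higher number from compound 2 to compound 4 (0.56 log units; beyond the scatter). The two groups match in heavy atoms, double bonds, hydrogen-bond donors and acceptors, so this place responds, modestly but beyond the scatter, to how the same atoms are joined and not only to which atoms are present. Even so, compound 4 does not join compound 1, which is the only member given as a limit: the limit of > 10 ug/mL in this assay, at which 1 of the 4 values shown sits.

Among the compounds shown here, the single step cannot separate the loss of the defined stereocentre from the new placement of the double bond and the acetate, so the share of each stays unknown. The compounds shown also leave open how a 3-hydroxyprop-1-en-1-yl group, a 3-aminoprop-1-en-1-yl group or a longer chain would fare at this same place on the triple-bonded carbon.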